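The compounds below may be only part of what the source reports. "The series", "measured", "known", "first", "only" and "open" are said of these compounds alone.

Measured so far:
- compound 1, `Cc1ccc(-c2ccc(Cl)c(C(=O)NCC3(O)CCCCCC3)c2)nn1`: 18 nM
- compound 2, `N#Cc1cccc(-c2ccc(Cl)c(C(=O)NCC3(O)CCCCCC3)c2)n1`: 232 nM

Two compounds share a core and differ only in the aromatic group attached to it. In a functional assay on HEK293 cells for antagonist activity at P2X purinoceptor 7 (Homo sapiens) (a higher number here means a weaker inhibitor, a lower number a stronger inhibitor), compound 1 gives 18 nM and stands as the lower of the two numbers; compound 2 gives 232 nM, and the step of a 13-fold higher number from compound 1 to compound 2 (1.11 log units; beyond the scatter) is large and well beyond the scatter.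

Compound 3, `O=C(NCC1(O)CCCCCC1)c1cc(-c2ccc(Cl)cn2)ccc1Cl`, has not yet been measured in this assay. It differs from compound 1 as follows: 5-chloropyridin-2-yl in place of 6-methylpyridazin-3-yl on an aromatic carbon

Going by the values given here, only one measured step bears on this change: a 13-fold higher number from compound 1 to compound 2 (1.11 log units; beyond the scatter), in which the 6-methylpyridazin-3-yl group also gave way to a substituted pyridinyl group and the number rose sharply. Compound 3 carries 5-chloropyridin-2-yl rather than 6-cyanopyridin-2-yl, so the two changes are related but not the same, and a smaller rise than in that step is expected, though still in the same direction. Because of a 13-fold higher number from compound 1 to compound 2 (1.11 log units; beyond the scatter), compound 3 is expected to show a 3.3-fold higher number from compound 1 to compound 3 (0.52 log units; beyond the scatter) in this assay. The estimate for compound 3 is 60 nM, with a range from 15 nM to 250 nM.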

Compound 3, half-maximal inhibitory concentration: 56 nM
The estimate for compound 3 lay 1.1-fold (0.03 log units) above the measured number; low and high end bracket the measured number.
By their numbers in this assay, from the lowest: compound 1; then compound 3; then compound 2.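

In this assay, the move to 5-chloropyridin-2-yl gives a 3.1-fold higher number from compound 1 to compound 3 (0.49 log units; beyond the scatter) and so shows that a second substituted pyridinyl group also stands above the 6-methylpyridazin-3-yl group, leaving compound 1 with the lowest number of the three. The position also separates the two pyridinyl groups from each other, with a 4.1-fold lower number from compound 2 to compound 3 (0.62 log units; beyond the scatter) showing that the pyridinyl groups do not behave as one class here and that what the ring carries, where it carries it, or both, matter to the number. Nothing measured here explains either step or the order of the three groups.

The compounds shown leave open whether the gap between compound 2 and compound 3 follows the exchange of nitrile for chloro or the shift from the 6-position to the 5-position, as the two groups differ in both at once. They also leave open how an unsubstituted pyridazin-3-yl group, or a 6-methylpyridin-3-yl group with its methyl kept and one ring nitrogen removed, would compare with compound 1.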